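This account rests on a few compounds, and the source may have more. Where it says the series, first, only, none or still open, it means among the compounds named here.

Compound 1 `O=C1O/C(=C\Cn2cc(C(F)(F)F)c(=O)[nH]c2=O)C(OCc2ccccc2)=C1OCc1ccccc1`, compound 2 `O=C1O/C(=C\Cn2cc(I)c(=O)[nH]c2=O)C(OCc2ccccc2)=C1OCc1ccccc1` and compound 3 `O=C1O/C(=C\Cn2ccc(=O)[nH]c2=O)C(OCc2ccccc2)=C1OCc1ccccc1` share one core and differ only in the group on a single aromatic carbon. Among the measured compounds shown here, in a functional assay on HEp-2 cells (Homo sapiens) for inhibition (on this read-out lower numbers stand for stronger inhibition and higher numbers for weaker inhibition), compound 1 gives 40000 nM and compound 2 gives 10000 nM, so compound 2 holds the lower of the two numbers measured so far. Compound 3 carries hydrogen in place of iodo on an aromatic carbon. For the measured compounds named here, only one measured step bears on this change: a 4.0-fold lower number from compound 1 to compound 2 (0.60 log units; beyond the scatter), with iodo in place of trifluoromethyl on an aromatic carbon. Going by the values given here, that step swaps one group for another, and no measured compound shows the effect of leaving this carbon with hydrogen, so it offers only a loose guide to size. Among the compounds with values here, the lower number so far belongs to compound 2 with iodo at 10000 nM, which points to a modest move towards a higher number in this assay. The expected change is a 2.5-fold higher number from compound 2 to compound 3 (0.40 log units; beyond the scatter), although it could stay within the scatter. Compound 3 is therefore estimated at 25000 nM, with an expected range from 8000 nM to 80000 nM.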

Compound 3, half-maximal inhibitory concentration: 40000 nM
For compound 3 the middle estimate is 1.6-fold (0.20 log units) below the measured one; the measured number falls inside the stated range.
By their numbers in this assay, from the lowest: compound 2; then compounds 1 and 3 (each within the scatter of the next).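

In this assay replacing iodo with hydrogen gives a 4.0-fold higher number from compound 2 to compound 3 (0.60 log units; beyond the scatter) and so supplies the reference the earlier pair lacked: the lower number of compound 2 now reads as a gain tied to iodo on this aromatic carbon, not only as a difference from trifluoromethyl. The same replacement of trifluoromethyl gives no change at the digits printed from compound 1 to compound 3 (within the scatter) and shows that, on this read-out, trifluoromethyl cannot be told apart from hydrogen at this position. Among these three compounds, then, filling this carbon with a group other than hydrogen does not by itself lower the number: compound 2 fits such a pattern, but compound 1 goes against it, and the one step beyond the scatter in either direction involves iodo.

The compounds shown leave open whether other groups on this carbon, such as bromo, chloro, an amine or a longer chain, would side with iodo or with hydrogen and trifluoromethyl. No supporting data are available that bear on why iodo alone stands apart from the other two groups.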